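The compounds below may be only part of what the source reports. "The series", "measured", "known", "first", "only" and "open" are said of these compounds alone.

Series notes, cytotoxicity on rat muscle cells.

Compound 1 `O=C1CC2(N3CCCC3)CC(c3ccccc3)C1C(c1ccccc1)C2` and compound 2 `O=C1CC2(N3CCCCC3)CC(c3ccccc3)C1C(c1ccccc1)C2` share a core; compound 2 carries piperidin-1-yl in place of pyrrolidin-1-yl on a saturated ring carbon. In an ADME assay on L6 cells (Rattus norvegicus) for cytotoxicity (on this read-out lower numbers stand for stronger inhibition and higher numbers for weaker inhibition), compound 1 gives 26500 nM, and compound 2 gives 46900 nM; the step is a 1.8-fold higher number from compound 1 to compound 2 (0.25 log units; within the scatter).

Compound 3 `COc1ccc(C2CC3(N4CCCC4)CC(O)C2C(c2ccc(OC)cc2)C3)cc1` has a different core; the difference between the two cores is not broken down here. In this assay compound 3 gives 17900 nM, the lowest of the three numbers, within the scatter of compound 1 and beyond the scatter of compound 2.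

Compound 4 `COc1ccc(C2CC3(N4CCCCC4)CC(O)C2C(c2ccc(OC)cc2)C3)cc1` is not yet measured. It carries piperidin-1-yl in place of pyrrolidin-1-yl on a saturated ring carbon. This is the same kind of change as that from compound 1 to compound 2, though the surroundings differ: here the ring atom bearing a 4-methoxyphenyl group and a ring atom bearing a hydroxy group, there a ring atom bearing a phenyl group. Among the measured compounds shown here, with only one earlier instance, the step from compound 3 to compound 4 is expected to be a 1.8-fold higher number from compound 3 to compound 4 (0.25 log units; within the scatter), resting on compound 1 to compound 2 giving a 1.8-fold higher number from compound 1 to compound 2 (0.25 log units; within the scatter). Compound 4 is accordingly expected at 32000 nM, between 16000 nM and 64000 nM.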

Compound 4, half-maximal inhibitory concentration: 44600 nM
Beside the measured number, compound 4's estimate is 1.4-fold (0.14 log units) below it; the range from low to high includes it.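

In this assay, piperidin-1-yl in place of pyrrolidin-1-yl on a saturated ring carbon gives a 2.5-fold higher number from compound 3 to compound 4 (0.40 log units; beyond the scatter), whereas the same change on the core of compound 1 stayed within the scatter. The two steps point the same way, and the gap between them is no larger than repeated measurements of such steps would allow, so the change carries over between these two cores without a measurable difference: the same change on two cores in this assay, a 1.8-fold higher number (0.25 log units; within the scatter) from compound 1 to compound 2 and a 2.5-fold higher number (0.40 log units; beyond the scatter) from compound 3 to compound 4, 1.4-fold (0.15 log units) apart, within the scatter of two such steps. This rests on a single pair per core and shows neither that the step holds on any further core nor that the step is truly larger on the core of compound 3.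

The two cores differ in both the aryl groups and the carbonyl or hydroxy group, and the compounds shown do not separate what each of these contributes. On these data alone, it also remains open how the read-out responds on either core to an amine of another kind on that carbon, such as morpholin-4-yl or an open-chain dimethylamino group.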